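The source may hold more compounds than are shown below. What is called first, only, known or untested is meant among the compounds shown, and "the series" means these compounds.

In a functional assay on A549 cells (Homo sapiens) for inhibition, read by sulforhodamine B assay, with a stated time of 72 h (a higher number here means a weaker inhibitor of growth, a lower number a stronger inhibitor of growth), compound 1 (`CCOC(=O)/C=C/c1ccncc1-c1ccc2[nH]ccc2c1`) gives 7440 nM and stands at the weak end of this small set, together with compound 2 (`CCOC(=O)/C=C/c1ccncc1-c1ccc2cc[nH]c2c1`), which gives 5740 nM and lies within the scatter of compound 1. Within the data shown here, compound 3 (`CCOC(=O)/C=C/c1ccncc1-c1ccc2c(ccn2C)c1`) gives 1720 nM and is the one clearly lower number of the three.

The next compound, compound 4 (`CNC(=O)/C=C/c1ccncc1-c1ccc2[nH]ccc2c1`), keeps the core of compound 1 and changes only the ester end: methylamino in place of ethoxy on a carbonyl carbon. In words, methylamino stands in place of ethoxy on a carbonyl carbon, so the ester becomes an amide.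

Among the measured compounds shown here, no measured step touches this carbonyl, which leaves the evidence thin. For the measured compounds named here, the one step available is a 4.3-fold lower number from compound 1 to compound 3 (0.64 log units; beyond the scatter) and it comes from methyl in place of hydrogen on an aromatic nitrogen, at a different place in the molecule. That modest step took away a hydrogen on nitrogen and the number fell, whereas compound 4 gains a hydrogen-bond donor, so a modest move to a higher number is the cautious guess, though no change beyond the scatter remains possible. The expected size is a 1.5-fold higher number from compound 1 to compound 4 (0.17 log units; within the scatter) in this assay and this is only an estimate. Compound 4 is expected at 11000 nM with an estimated range from 3000 nM to 40000 nM.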

Compound 4, concentration for 50% growth inhibition: > 10000 nM
Compound 4: a limit, no number; the forecaster's own chance of this, stated with the estimate: 15%; the middle value does not contradict the limit.
By their numbers in this assay, from the lowest: compound 3; then compounds 2 and 1 (each within the scatter of the next). At a limit, above all of these: compound 4.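

Among these compounds, this is the first change at the carbonyl end of the molecule. In this assay compound 4 gives > 10000 nM, which is a limit of the assay and not a number. Read as a step, methylamino in place of ethoxy on a carbonyl carbon gives an at least 1.3-fold higher number from compound 1 to compound 4 (0.12 log units; that floor lies within the scatter), so turning the ester into an amide brought no lower number at this place, unlike the methyl step on the aromatic nitrogen, and the true size of the change stays hidden behind one reading: the limit of > 10000 nM in this assay, at which 1 of the 4 values shown sits.

From the compounds shown here alone, whether a carboxylic acid or a dimethylamino group on the same carbonyl carbon would sit closer to the ester or to the amide stays open, as does the effect of a longer chain on the amide nitrogen. Equally open, going by these compounds, is whether methyl on the aromatic nitrogen, the change that leads from compound 1 to compound 3, would still lower the number when the carbonyl carbon carries methylamino instead of ethoxy.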